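A few compounds are considered here, and "the series" means these few. Any claim that something is new, unique, unknown or untested is made for them only; others in the source may bear on it.

Compound 1 `O=C(Nc1cc(Sc2ncn[nH]2)c(O)c2ccccc12)c1ccc([N+](=O)[O-])cc1`: > 100000 nM
Compound 2 `O=C(Nc1cc(Sc2ncn[nH]2)c(O)c2ccccc12)c1cccc([N+](=O)[O-])c1`: 48000 nM
Compound 3 `O=C(Nc1cc(Sc2ncn[nH]2)c(O)c2ccccc12)c1ccc2ccccc2c1`: 45100 nM

In a functional assay on MDA-MB-231 cells (Homo sapiens) for antiproliferative activity, read by MTT assay, with a stated time of 48 h (on this read-out higher numbers stand for weaker inhibition and lower numbers for stronger inhibition), compound 3 gives 45100 nM, the lowest of the two numbers shown. Compound 2 sits within the scatter of it, at 48000 nM. The value of compound 1 is a limit of this assay, > 100000 nM, and not a number.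

Compound 4 `O=C(Nc1cc(Sc2ncn[nH]2)c(O)c2ccccc12)c1cccc(Cl)c1` differs from compound 3 only on the carbonyl carbon: 3-chlorophenyl in place of naphthalen-2-yl on a carbonyl carbon. The measured steps on that same carbonyl carbon are the ones that bear on it. From compound 1 the change to compound 3 gave an at least 2.2-fold lower number from compound 1 to compound 3 (0.34 log units; beyond the scatter), and to compound 2 gave an at least 2.0-fold lower number from compound 1 to compound 2 (0.31 log units; beyond the scatter); both rest on a limit of > 100000 nM in this assay, at which 1 of the 3 values shown sits, and so mark only a lower bound. The step that most resembles the present one, a single six-membered ring with one substituent in place of the two fused rings, was a 1.1-fold lower number from compound 2 to compound 3 (0.03 log units; within the scatter).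

On that footing compound 4 is expected to stay close to compound 3, with a 1.1-fold higher number from compound 3 to compound 4 (0.04 log units; within the scatter), a step not beyond the scatter in this assay. The estimate for compound 4 is 50000 nM, between 20000 nM and 120000 nM.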

Compound 4, half-maximal inhibitory concentration: > 100000 nM
Compound 4 was reported as a limit (the forecaster's own chance of this, stated with the estimate: 30%); middle value at least 2.0-fold (0.30 log units) away from the limit.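

With 3-chlorophenyl on the carbonyl carbon in this assay, the result is an at least 2.2-fold higher number from compound 3 to compound 4 (0.34 log units; beyond the scatter), so a single ring bearing one substituent does not automatically match naphthalen-2-yl, even though the 3-nitrophenyl of compound 2 had stood within the scatter of it. Chloro in place of nitro on an aromatic carbon, with the rest of the structure unchanged, gives an at least 2.0-fold higher number from compound 2 to compound 4 (0.31 log units; beyond the scatter), which shows that the identity of this substituent matters and not only the place it occupies, a point the earlier comparison of the two nitrophenyl groups could not show. The step between compound 1 and compound 4 cannot be read, and the two readable steps give only a minimum size, each resting on a limit: the limit of > 100000 nM in this assay, at which 2 of the 4 values shown sit.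

Going by these compounds, what an amine or a carboxylic acid on this ring would do remains open, as does the effect of unsubstituted phenyl or a longer chain on the carbonyl carbon. The compounds shown also leave open how far compound 4 truly lies from compound 2 and compound 3, and whether any group at this position can give a much lower number.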